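Working notes: hydrogen for chloro, compound 3 to compound 4

The compounds below may be only part of what the source reports. "The series", "measured", "known", "first", "only" and "open" are said of these compounds alone.

Measured so far, in a functional assay on FOCUS cells (Homo sapiens) for inhibition, read by sulforhodamine B assay, with a stated time of 72 h; a lower number here means a stronger inhibitor, a higher number a weaker inhibitor: compound 1 `Cc1ccc(C2=Nn3c(nnc3C(C)c3ccc(CC(C)C)cc3)SC2)cc1` gives 6800 nM; compound 2 `CC(C)Cc1ccc(C(C)c2n[nH]c(=S)n2N)cc1` is reported as "not active" (no number reported); compound 3 `CC(c1ccc(-c2ccccc2)c(F)c1)c1nnc2n1N=C(c1ccc(Cl)cc1Cl)CS2` gives 5400 nM.

Compound 3 holds the lower of the two numbers, but compound 1 sits within the usual scatter of it, so no order between the two can be read; compound 2 carries no number at all.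

Compound 4 `CC(c1ccc(-c2ccccc2)c(F)c1)c1nnc2n1N=C(c1ccc(Cl)cc1)CS2` differs from compound 3 by hydrogen in place of chloro on an aromatic carbon. Within the data shown here, no pair of measured compounds shows this change, and the two numbers available give no direction. A step within the scatter is therefore expected, a 1.3-fold higher number from compound 3 to compound 4 (0.11 log units; within the scatter). Compound 4 is estimated at 7000 nM, in the range 2500 nM to 20000 nM.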

Compound 4, half-maximal inhibitory concentration: 5000 nM
Beside the measured number, compound 4's estimate is 1.4-fold (0.15 log units) above it; the measured number falls inside the stated range.
By their numbers in this assay, from the lowest: compounds 4, 3 and 1 (each within the scatter of the next).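

Going from 2,4-dichlorophenyl to 4-chlorophenyl gives, in this assay, a 1.1-fold lower number from compound 3 to compound 4 (0.03 log units; within the scatter). Among these compounds, this is the first single-place comparison, and at this position, ortho to a large group, chloro and hydrogen cannot be told apart by these numbers. No data at hand offer a reason for this result.

On these data alone, whether the remaining chloro group can also be replaced by hydrogen stays open. So does whether a methoxy group or an amine on this ring would give a step beyond the scatter.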